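Swapping a methylpiperidine for a sulfonamide-capped chain

This account rests on a few compounds, and the source may have more. Where it says the series, first, only, none or still open, it means among the compounds named here.

Among the measured compounds shown here, compound 3 `CC1CCCN(C(=O)CN2CN(c3ccccc3)C3(CCN(C(=O)c4ccc(C(C)(C)C)cc4)CC3)C2=O)C1` gives 12000 nM in an assay on HEK293 cells for displacement of a labelled ligand from NPC1-like intracellular cholesterol transporter 1 (Homo sapiens) (a lower number here means a stronger inhibitor, a higher number a weaker inhibitor), the highest of the three numbers measured so far. Compound 1 `CC(C)(C)OC(=O)NCCNC(=O)CN1CN(c2ccccc2)C2(CCN(C(=O)c3ccc(C(C)(C)C)cc3)CC2)C1=O` gives 10900 nM, and compound 2 `CC(C)(C)OC(=O)NCCCNC(=O)CN1CN(c2ccccc2)C2(CCN(C(=O)c3ccc(C(C)(C)C)cc3)CC2)C1=O` gives 4500 nM. The step of a 2.7-fold higher number from compound 2 to compound 3 (0.43 log units; beyond the scatter) lies beyond the scatter, whereas a 1.1-fold higher number from compound 1 to compound 3 (0.04 log units; within the scatter) does not; the chain-lengthening step a 2.4-fold lower number from compound 1 to compound 2 (0.38 log units; beyond the scatter) is likewise modest. Compound 4 `CC(C)(C)c1ccc(C(=O)N2CCC3(CC2)C(=O)N(CC(=O)NCCCCCNS(C)(=O)=O)CN3c2ccccc2)cc1` carries (5-(methanesulfonamido)pentyl)amino in place of 3-methylpiperidin-1-yl on a carbonyl carbon. Both open-chain amides, compound 1 and compound 2, gave numbers no higher than compound 3, and the longer chain gave the lower one, so the still longer chain of compound 4 bears on this change. Compound 4 is therefore expected to show a modestly lower number, a step of a 2.7-fold lower number from compound 3 to compound 4 (0.43 log units; beyond the scatter). Compound 4 is estimated at 4500 nM, with a range from 1500 nM to 13000 nM.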

Compound 4, half-maximal inhibitory concentration: 5500 nM
For compound 4 the middle estimate is 1.2-fold (0.09 log units) below the measured one, within the range that was stated.
By their numbers in this assay, from the lowest: compounds 2, 4, 1 and 3 (each within the scatter of the next, the first and the last beyond it).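

In this assay, the methanesulfonamide-capped pentyl amide also gives a lower number than the 3-methylpiperidin-1-yl amide (a 2.2-fold lower number from compound 3 to compound 4 (0.34 log units; beyond the scatter)), so this is not confined to the tert-butoxycarbonyl-capped compound 2. Replacing that cap and lengthening the chain together leaves the number within the scatter of both carbamates (a 1.2-fold higher number from compound 2 to compound 4 (0.09 log units; within the scatter); a 2.0-fold lower number from compound 1 to compound 4 (0.30 log units; within the scatter)). No supporting evidence explains these steps. On these data alone, because cap and chain length change together here, their separate contributions remain open. Also open, as far as these compounds go, is whether a carboxylic acid, an amine or a longer chain on this carbonyl carbon would give a lower number.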